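Compound 3: carbonyloxy link in place of carbamoyl

This account rests on a few compounds, and the source may have more. Where it says the series, first, only, none or still open, it means among the compounds named here.

- Compound 1 `CCCCCCCCCCCC[C@@H](O)[C@H]1CC[C@H]([C@H](O)CCCCCCCCCCNCc2ccnn2C)O1`: 1510 nM
- Compound 2 `CCCCCCCCCCCC[C@@H](O)[C@H]1CC[C@H]([C@H](O)CCCCCCCCCCC(=O)Nc2ccnn2C)O1`: 100000 nM

In a functional assay on U-251 cells (Homo sapiens) for inhibition, read by sulforhodamine B assay, with a stated time of 48 h (on this read-out higher numbers stand for weaker inhibition of growth and lower numbers for stronger inhibition of growth), the higher of the two numbers belongs to compound 2 at 100000 nM, which means the weaker inhibition of growth of the pair.

The next compound is compound 3 `CCCCCCCCCCCC[C@@H](O)[C@H]1CC[C@H]([C@H](O)CCCCCCCCCCOC(=O)c2ccnn2C)O1`, which changes only the link on the chain of compound 2: ((1-methyl-1H-pyrazol-5-yl)carbonyl)oxy in place of (1-methyl-1H-pyrazol-5-yl)carbamoyl on a saturated chain carbon, ten or more bonds along the chain from an oxygen on a saturated carbon and a saturated ring carbon. The change lies on a saturated chain carbon.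

Among the measured compounds shown here, one measured step bears on it, a 66-fold higher number from compound 1 to compound 2 (1.82 log units; beyond the scatter). This step is large and beyond the scatter, and it falls at the same place on the chain. It shows that this assay can respond strongly to a change there, but it involves an amine link, and no ester has been measured. A move to a lower number is expected, smaller than that measured step, and the uncertainty is wide. The expected step is a 3.3-fold lower number from compound 2 to compound 3 (0.52 log units; beyond the scatter). For compound 3 the estimate is 30000 nM, with an expected range of 5000 nM to 100000 nM.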

Compound 3, concentration for 50% growth inhibition: 69200 nM
Compound 3: the middle estimate sits 2.3-fold (0.36 log units) below what was measured; measured number inside the range.
By their numbers in this assay, from the lowest: compound 1; then compounds 3 and 2 (each within the scatter of the next).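

In this assay, the carbonyloxy link of compound 3 and the carbamoyl link of compound 2 read alike, with a 1.4-fold lower number from compound 2 to compound 3 (0.16 log units; within the scatter), so reversing the link and removing the amide hydrogen makes no difference that this read-out can resolve at this position. The second comparison, a 46-fold higher number from compound 1 to compound 3 (1.66 log units; beyond the scatter), shows that the large gap to compound 1 is not confined to the amide: among these three compounds, only the ((1-methyl-1H-pyrazol-5-yl)methyl)amino link goes with the low number, and neither of the two carbonyl-containing links comes close to it. No measured evidence is available here to account for this pattern.

The compounds shown leave open whether the number for compound 1 depends on the amine alone or on the amine together with the 1-methyl-1H-pyrazol-5-yl group, a question that a chain ending in a primary amine or a benzylamino group at the same place would address. Also open, on these data alone, is how a carboxylic acid at this chain end, or a longer chain carrying the same amine link, would read in this assay on the shared core.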